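The source may hold more compounds than are shown below. What is called first, only, known or untested is meant among the compounds shown, and "the series" means these compounds.

Measured so far in a functional assay on SW-620 cells (Homo sapiens) for inhibition; on this read-out lower numbers stand for stronger inhibition of growth and higher numbers for weaker inhibition of growth:
Compound 1 `C=C1C(=O)O[C@H]2[C@H]1CC/C(COC(=O)N1CCC(F)(F)CC1)=C\CC[C@@]1(C)O[C@@H]21`: 1460 nM
Compound 2 `C=C1C(=O)O[C@H]2[C@H]1CC/C(COC(=O)NCCN1CCCC1)=C\CC[C@@]1(C)O[C@@H]21`: 3460 nM

Of these two compounds, compound 2 has the higher number, 3460 nM, so it inhibits growth less strongly than compound 1. The next compound to be tested is compound 3 `C=C1C(=O)O[C@H]2[C@H]1CC/C(COC(=O)Nc1n[nH]c(SC)n1)=C\CC[C@@]1(C)O[C@@H]21`. It keeps the shared core and carries 5-(methylsulfanyl)-1H-1,2,4-triazol-3-yl in place of 2-(pyrrolidin-1-yl)ethyl on an amide-type nitrogen.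

Going by the values given here, only one measured step bears on this change: a 2.4-fold higher number from compound 1 to compound 2 (0.37 log units; beyond the scatter). That modest step brought in the same 2-(pyrrolidin-1-yl)ethyl group that compound 3 gives up. Among the compounds with values here, no measured compound carries the triazole group, so this single step is a thin guide. Even so, it suggests that replacing this group could bring the number down by a similarly modest amount, though the direction remains uncertain. The expected step is a 1.9-fold lower number from compound 2 to compound 3 (0.28 log units; within the scatter) in this assay. For compound 3, the estimated value is 1800 nM, with an expected range of 600 nM to 4800 nM.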

Compound 3, concentration for 50% growth inhibition: 1120 nM
Compound 3: middle estimate off by 1.6-fold (0.21 log units), on the high side, within the range that was stated.
By their numbers in this assay, from the lowest: compounds 3 and 1 (each within the scatter of the next); then compound 2.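

In this assay, putting 5-(methylsulfanyl)-1H-1,2,4-triazol-3-yl on the amide-type nitrogen in place of 2-(pyrrolidin-1-yl)ethyl gives a 3.1-fold lower number from compound 2 to compound 3 (0.49 log units; beyond the scatter), the first measured exchange made on that nitrogen itself, and it shows that growth inhibition responds to the group carried there. The comparison with the 4,4-difluoropiperidin-1-yl group on the carbonyl carbon gives a 1.3-fold lower number from compound 1 to compound 3 (0.12 log units; within the scatter), so two quite different groups sit level within the scatter, and compound 2 is the weakest of the three, with its steps to both others beyond the scatter. Nothing measured here explains why the 2-(pyrrolidin-1-yl)ethyl group stands apart from the other two.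

Going by these compounds, it stays open whether the lower number of compound 3 comes from the aromatic ring or from the methylsulfanyl group on it; the same ring bearing only hydrogen, or a plain phenyl ring on that nitrogen, would help separate the two. On these data alone, it is equally open whether the pyrrolidine ring or the two-carbon chain holds compound 2 back, which a 2-(dimethylamino)ethyl group or a simple butyl chain could begin to test.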